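The source may hold more compounds than are shown below. What is called first, only, known or untested is meant among the compounds shown, and "the series" means these compounds.

Measured so far:
- Compound 1, `Cc1ccc(/C=C2\CCC/C(=C\c3ccc([N+](=O)[O-])cc3)C2=O)cc1`: 8530 nM
- Compound 2, `O=C1/C(=C/c2ccc(F)cc2)CCC/C1=C\c1ccc([N+](=O)[O-])cc1`: 18600 nM

Both numbers come from a functional assay on CCRF-CEM cells (Homo sapiens) for cytotoxicity, with a stated time of 72 h; on this read-out higher numbers stand for weaker inhibition and lower numbers for stronger inhibition. Of the two, compound 2 gives the higher number, separated from compound 1 by a gap that is beyond the usual scatter.

Compound 3, `O=C1/C(=C/c2ccc(Cl)cc2)CCC/C1=C\c1ccc([N+](=O)[O-])cc1`, has not yet been measured. It differs from compound 2 in one place: chloro in place of fluoro on an aromatic carbon. For the measured compounds named here, only one measured step touches this part of the shared core, the swap of methyl for fluoro at the same carbon, which gave a 2.2-fold higher number from compound 1 to compound 2 (0.34 log units; beyond the scatter). Going by the values given here, that step says that a change at this carbon can shift the number by a modest amount, but it does not say in which direction a chloro would move it, since no chloro compound has been measured. The expected step of a 1.7-fold lower number from compound 2 to compound 3 (0.23 log units; within the scatter) is therefore small and uncertain, leaning toward a lower number as a return toward compound 1. Compound 3 is estimated at 11000 nM in this assay, with a likely range of 4500 nM to 28000 nM.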

Compound 3, half-maximal inhibitory concentration: 8180 nM
For compound 3 the middle estimate is 1.3-fold (0.13 log units) above the measured one, and the stated range covers the measured number.
By their numbers in this assay, from the lowest: compounds 3 and 1 (each within the scatter of the next); then compound 2.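

In this assay, the change from 4-fluorophenyl to 4-chlorophenyl gives a 2.3-fold lower number from compound 2 to compound 3 (0.36 log units; beyond the scatter) and so shows that a new group at this carbon can reverse the earlier rise. Against the methyl group, chloro gives a 1.0-fold lower number from compound 1 to compound 3 (0.02 log units; within the scatter) and cannot be told apart from it here, so among the three groups shown only fluoro stands out, with the highest number. No measurement at hand explains why fluoro differs from the other two.

The compounds shown leave open whether an amine, a methoxy group or a carboxylic acid at this carbon would stay level with methyl and chloro or move the number further. They also leave open whether these steps would keep their size if the nitro group elsewhere on the shared core were replaced by another group, such as a nitrile.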